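Series notes: the step from compound 1 to compound 3

The compounds below may be only part of what the source reports. "The series", "measured", "known", "first", "only" and "open" are said of these compounds alone.

Compound 1 `O=C(/C=C\Nc1ccc2cc[nH]c2c1)c1nc(-c2ccc(C(F)(F)F)cc2)n2ccccc12` carries 1H-indol-6-yl on the amine nitrogen. In a functional assay on B16-F10 cells (Mus musculus) for cytotoxicity, read by MTT assay, with a stated time of 48 h (a higher number here means a weaker inhibitor, a lower number a stronger inhibitor), compound 1 returns only the assay limit, > 30000 nM, and not a number. Compound 2 `Cc1cc2cc(N/C=C\C(=O)c3nc(-c4ccc(F)cc4)n4ccccc34)ccc2[nH]1` is the other measured member of the set. In this assay compound 2 also stops at the limit, > 30000 nM. Both shown values thus sit at the limit of > 30000 nM in this assay, at which 2 of the 2 values shown sit, so compound 1 can be placed no better than that ceiling, and no step between measured compounds can be sized from these data. Compound 3 `COc1ccc(N/C=C\C(=O)c2nc(-c3ccc(C(F)(F)F)cc3)n3ccccc23)cc1` differs from compound 1 by 4-methoxyphenyl in place of 1H-indol-6-yl on an amine nitrogen. With nothing measured to rest on, the expected step that the limit leaves unreadable from compound 1 to compound 3 is none beyond the scatter, because compound 1 gives > 30000 nM and nothing in the set points away from the ceiling. In this assay compound 3 is estimated at 40000 nM, with a range from 10000 nM to 150000 nM, most likely reported again only as a limit.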

Compound 3, half-maximal inhibitory concentration: > 30000 nM
Compound 3 ended at the assay's limit; the forecaster's own chance of this, stated with the estimate: 80%; the middle value lies beyond the limit too.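

No step from compound 1 to compound 3 can be read in this assay, since both results are limits of the assay and not numbers: the limit of > 30000 nM in this assay, at which 3 of the 3 values shown sit.

The compounds shown leave open whether any group on the amine nitrogen gives a number rather than a limit.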